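The compounds below may be only part of what the source reports. "The series", "measured", "known", "first", "only" and "open" are said of these compounds alone.

Of the compounds shown here, three that share one core have been tested in an ADME assay on HepG2 cells (Homo sapiens) for cytotoxicity, read by luminescence, CellTiter-Glo and ATP content, with a stated time of 72 h; on this read-out lower numbers stand for an effect already at smaller amounts and higher numbers for an effect only at larger amounts of compound. Compound 1 `COc1ccc(Oc2ccc3c(NCCCNCc4ccco4)ccnc3c2)cc1` gives 5300 nM, compound 2 `Fc1ccc(Cc2ccc3c(NCCCNCc4ccco4)ccnc3c2)cc1` gives 5600 nM, and compound 3 `COc1cccc(Oc2ccc3c(NCCCNCc4ccco4)ccnc3c2)c1` gives 15500 nM, the highest of the three numbers. Compound 4 `c1coc(CNCCCNc2ccnc3cc(C4CCCCC4)ccc23)c1` differs from compound 3 at that same aromatic carbon: cyclohexyl in place of 3-methoxyphenoxy on an aromatic carbon. Two measured steps change this position: a 2.9-fold higher number from compound 1 to compound 3 (0.47 log units; beyond the scatter) and a 2.8-fold higher number from compound 2 to compound 3 (0.44 log units; beyond the scatter), both modest. The step of a 1.1-fold higher number from compound 1 to compound 2 (0.02 log units; within the scatter) shows that a swap at this carbon can also leave the number essentially where it was. None of these steps brings in a cyclohexyl, so the direction is uncertain. A modest move is expected for compound 4, most likely a 1.9-fold lower number from compound 3 to compound 4 (0.29 log units; within the scatter), giving an estimate of 8000 nM with a range from 3000 nM to 22000 nM.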

Compound 4, half-maximal effective concentration in the HepG2 assay: 4760 nM
Compound 4: the middle estimate sits 1.7-fold (0.23 log units) above what was measured, within the range that was stated.
By their numbers in the HepG2 assay, from the lowest: compounds 4, 1 and 2 (each within the scatter of the next); then compound 3.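

In the HepG2 assay cyclohexyl, a non-aromatic ring with no hydrogen-bond acceptors, gives a 3.3-fold lower number from compound 3 to compound 4 (0.51 log units; beyond the scatter) but also a 1.2-fold lower number from compound 2 to compound 4 (0.07 log units; within the scatter) and a 1.1-fold lower number from compound 1 to compound 4 (0.05 log units; within the scatter) so compound 3 alone stands apart. An aromatic ring at this carbon is therefore not required for a number at the level of compound 1 and compound 2. In a physicochemical assay for solubility, with a stated time of 18 h, at pH 7.4 (on this read-out lower numbers stand for lower solubility and higher numbers for higher solubility), compound 3 gives 14500 nM and compound 4 gives 4200 nM so this swap also lowers solubility: the measured solubility of compound 3, 14500 nM, and of compound 4, 4200 nM, a 3.5-fold lower number (0.54 log units; beyond the scatter).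

From the compounds shown here alone, how an amine or a carboxylic acid at this aromatic carbon would behave on either read-out remains open.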